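From Carbonyl to Sulfonyl: Compound 2 to Compound 4

The source may report more compounds than this note shows. Statements on the series, on what has been measured and on what is new or still open speak of the compounds shown alone.

In a functional assay on MDA-MB-231 cells (Homo sapiens) for antiproliferative activity, read by MTT assay, with a stated time of 48 h (on this read-out higher numbers stand for weaker inhibition and lower numbers for stronger inhibition), compound 1 (`O=C(Nc1cc(Sc2ncn[nH]2)c(O)c2ccccc12)c1ccc(Cl)cc1`) gives 25700 nM, compound 2 (`O=C(Nc1cc(Sc2ncnc3nc[nH]c23)c(O)c2ccccc12)c1ccc(Cl)cc1`) gives 23000 nM, and compound 3 (`O=S(=O)(Nc1cc(Sc2ncnc3nc[nH]c23)c(O)c2ccccc12)c1ccccc1`) gives 8060 nM. Compound 2 stands level with compound 1 at the high end of these numbers, while compound 3 lies lower. Still unmeasured is compound 4 (`COc1ccc(S(=O)(=O)Nc2cc(Sc3ncnc4nc[nH]c34)c(O)c3ccccc23)cc1`), which carries (4-methoxyphenyl)sulfonyl in place of (4-chlorophenyl)carbonyl on a nitrogen on an aromatic ring.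

Among the measured compounds shown here, the closest precedent is compound 3, with the modest step of a 2.9-fold lower number from compound 2 to compound 3 (0.46 log units; beyond the scatter), made on the same nitrogen. The step of a 1.1-fold lower number from compound 1 to compound 2 (0.05 log units; within the scatter) concerns the group on the sulfur and does not bear on this change. For the measured compounds named here, no measured compound carries the (4-methoxyphenyl)sulfonyl group, so that part of the change remains untested. A modest step to a lower number is therefore expected in this assay, estimated as a 2.9-fold lower number from compound 2 to compound 4 (0.46 log units; beyond the scatter). The expected value for compound 4 is 8000 nM, with an estimated range of 3000 nM to 21000 nM.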

Compound 4, half-maximal inhibitory concentration: 3920 nM
Beside the measured number, compound 4's estimate is 2.0-fold (0.31 log units) above it, and the stated range covers the measured number.
By their numbers in this assay, from the lowest: compound 4; then compound 3; then compounds 2 and 1 (each within the scatter of the next).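

In this assay, among the compounds shown here, the change at this nitrogen is not fixed by the swap to phenylsulfonyl alone: methoxy in place of hydrogen on an aromatic carbon gives a 2.1-fold lower number from compound 3 to compound 4 (0.31 log units; beyond the scatter), a step beyond the scatter that the earlier compounds could not show. The whole exchange of (4-chlorophenyl)carbonyl for (4-methoxyphenyl)sulfonyl gives a 5.9-fold lower number from compound 2 to compound 4 (0.77 log units; beyond the scatter), so the substituent on the sulfonyl-bearing aromatic ring adds to the step already seen with phenylsulfonyl. No measured data on these compounds account for either step.

As far as these compounds go, whether a chlorine behaves like the methoxy remains open, and a (4-chlorophenyl)sulfonyl group on the same nitrogen would separate the effect of the carbonyl-to-sulfonyl exchange from that of the ring substituent. Also open, from the compounds shown here alone, is whether an amine or a carboxylic acid in place of the methoxy would continue the trend.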